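A few compounds are considered here, and "the series" means these few. Any claim that something is new, unique, unknown or untested is made for them only; others in the source may bear on it.

In an ADME assay on MT4 cells (Homo sapiens) for cytotoxicity, read by MTT assay, with a stated time of 5 days (on this read-out higher numbers stand for lower toxicity in this test and lower numbers for higher toxicity in this test), three compounds sharing one core have been read so far. Compound 1 (`CNc1cc(Oc2c(OC)cc3cc(C#N)ccc3c2OC)nc(Nc2ccc(C#N)cc2)n1`) gives a measured number, 239000 nM. Compound 2 (`CCC(C)Nc1cc(Oc2c(OC)cc3cc(C#N)ccc3c2OC)nc(Nc2ccc(C#N)cc2)n1`) reports > 125000 nM, which is a limit of the assay. Compound 3 (`COc1cc2cc(C#N)ccc2c(OC)c1Oc1cc(NC2CCOCC2)nc(Nc2ccc(C#N)cc2)n1`) reports > 125000 nM, also a limit and not a number. Compound 3 therefore stands on (the limit of > 125000 nM in this assay, at which 2 of the 3 values shown sit).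

Compound 4 (`COc1cc2cc(C#N)ccc2c(OC)c1Oc1cc(NC2CCOC2)nc(Nc2ccc(C#N)cc2)n1`) differs from compound 3 in one place: oxolan-3-yl in place of oxan-4-yl on a nitrogen on an aromatic ring, (oxolan-3-yl in place of oxan-4-yl on a nitrogen on an aromatic ring). Both groups hold one non-aromatic ring with one hetero atom, and the entering ring is five-membered rather than six-membered.

The measured steps that bear on this change all concern the same nitrogen, and none has a readable size. They are a step that the limit leaves unreadable from compound 1 to compound 2, a step that the limit leaves unreadable from compound 1 to compound 3 and a step that the two limits leave unreadable from compound 2 to compound 3. Within the data shown here, the only number to lean on is that of compound 1, at 239000 nM, and it lies high in the range of this read-out.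

The expected step, a step that the limit leaves unreadable from compound 3 to compound 4, is estimated to stay within the scatter, with no direction to be expected. For compound 4 the estimated value is 150000 nM, with an expected range from 70000 nM to 300000 nM.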

Compound 4, half-maximal cytotoxic concentration: > 125000 nM
Compound 4 ended at the assay's limit (the forecaster's own chance of this, stated with the estimate: 60%); the middle value is on the limit's open side.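

Compound 4 ends at a limit of the assay, as compound 2 and compound 3 do, so no step from compound 1, compound 2 or compound 3 to compound 4 can be read in this assay: the limit of > 125000 nM in this assay, at which 3 of the 4 values shown sit.

The compounds shown leave open whether oxolan-3-yl, oxan-4-yl, sec-butyl and methyl on this nitrogen differ at all in this assay.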